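Mirror Image of an Inactive Compound in a Growth Test

The compounds below may be only part of what the source reports. "The series", "measured", "known", "first", "only" and "open" are said of these compounds alone.

Of the compounds shown here, three have been measured in an ADME assay on NIH3T3 cells (Mus musculus) for antiproliferative activity, read by sulforhodamine B assay, with a stated time of 48 h; a higher number here means a weaker inhibitor, a lower number a stronger inhibitor. Compound 1 `CC(C)(C)OC(=O)n1cnc(C[C@H]2N=C3C[C@H]4C[C@H](C4(C)C)[C@@]3(C)OC2=O)c1` reaches only a limit there, > 1300000 nM in this assay. Compound 2 `CC(C)(C)OC(=O)NCCC[C@@H]1N=C2C[C@@H]3C[C@@H](C3(C)C)[C@]2(C)OC1=O` likewise gives only a limit, > 1200000 nM. Compound 3 `CC(C)(C)OC(=O)NCCCC[C@H]1N=C2C[C@H]3C[C@H](C3(C)C)[C@@]2(C)OC1=O` also stops at a limit, > 1300000 nM. Its standing among the three therefore cannot be told apart from the others: the limit of > 1200000 nM in this assay, at which 1 of the 3 values shown sits, and the limit of > 1300000 nM in this assay, at which 2 of the 3 values shown sit, together account for every value shown, and none is a true number. Compound 4 `CC(C)(C)OC(=O)NCCCC[C@@H]1N=C2C[C@@H]3C[C@@H](C3(C)C)[C@]2(C)OC1=O` has not been measured; it differs from compound 3 in this way: the two compounds have the same atoms and bonds and differ only in configuration as drawn: 4 of 4 stereo elements differ (all stereocentres are inverted: mirror images); a stereocentre at a saturated ring carbon is drawn R in compound 3 and S in compound 4; a stereocentre at a saturated ring carbon is drawn R in compound 3 and S in compound 4; a stereocentre at a saturated ring carbon is drawn R in compound 3 and S in compound 4; a stereocentre at a saturated ring carbon is drawn R in compound 3 and S in compound 4. Within the data shown here, no step between measured compounds exists to gauge such a change, and no shift beyond the scatter is expected. For compound 4 the estimate is 1300000 nM, between 650000 nM and 1300000 nM, most likely again reported as a limit, which means an expected step of a number no higher from compound 3 to compound 4 (the limit leaves the size open).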

Compound 4, half-maximal inhibitory concentration: > 800000 nM
Compound 4 gave a limit, no number; the forecaster's own chance of this, stated with the estimate: 85%; the middle value is on the limit's open side.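

Among these compounds, compound 2, compound 3 and compound 4 all stop at limits, so no step to compound 4 can be read. Whether inverting every stereocentre changes activity in this assay stays open: no compound shown gives a true number.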